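The source may report more compounds than this note shows. Statements on the series, on what has been measured and on what is new or still open speak of the compounds shown alone.

Three close relatives of one shared core have been tested in a functional assay on MDA-MB-231 cells (Homo sapiens) for cytotoxicity, read by MTT assay, with a stated time of 48 h; on this read-out lower numbers stand for stronger inhibition and higher numbers for weaker inhibition. Compound 1, `CC(C)n1c(/C=C2/C(=O)Nc3ccc(F)cc32)nc2ccccc21`, gives 22700 nM. Compound 2, `Cn1c(/C=C2/C(=O)Nc3ccc(F)cc32)nc2ccccc21`, gives 21700 nM. Compound 3, `CC(C)n1c(/C=C2/C(=O)Nc3ccc(Cl)cc32)nc2ccccc21`, gives 25100 nM. Two single changes connect these three. The step of a 1.0-fold lower number from compound 1 to compound 2 (0.02 log units; within the scatter) goes with the change (methyl in place of isopropyl on an aromatic nitrogen). The step of a 1.1-fold higher number from compound 1 to compound 3 (0.04 log units; within the scatter) goes with chloro in place of fluoro on an aromatic carbon, and this is the whole of how the core of compound 1 and the core of compound 3 differ.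

Compound 4, `Cn1c(/C=C2/C(=O)Nc3ccc(Cl)cc32)nc2ccccc21`, has not yet been measured. It differs from compound 3 by methyl in place of isopropyl on an aromatic nitrogen. This is the same change that turns compound 1 into compound 2, and the surroundings of the place where it happens read alike word for word in both cases, so the two changes can be treated as one and the same. Because the step of a 1.0-fold lower number from compound 1 to compound 2 (0.02 log units; within the scatter) stayed within the scatter, the expected step is a 1.0-fold lower number from compound 3 to compound 4 (0.02 log units; within the scatter). Compound 4 is therefore estimated at 24000 nM in this assay, with a likely span from 12000 nM to 48000 nM.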

Compound 4, half-maximal inhibitory concentration: 37600 nM
For compound 4 the middle estimate is 1.6-fold (0.19 log units) below the measured one; the range from low to high includes it.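

In this assay, methyl in place of isopropyl on the aromatic nitrogen gives a 1.5-fold higher number from compound 3 to compound 4 (0.18 log units; within the scatter), and this agrees with the same change made on the fluoro compounds: the same change on two cores in this assay, a 1.0-fold lower number (0.02 log units; within the scatter) from compound 1 to compound 2 and a 1.5-fold higher number (0.18 log units; within the scatter) from compound 3 to compound 4, 1.6-fold (0.20 log units) apart, within the scatter of two such steps. Chloro in place of fluoro, read on the two compounds carrying methyl, gives a 1.7-fold higher number from compound 2 to compound 4 (0.24 log units; within the scatter), and this agrees with the same change read on the two compounds carrying isopropyl: the same change on two cores in this assay, a 1.1-fold higher number (0.04 log units; within the scatter) from compound 1 to compound 3 and a 1.7-fold higher number (0.24 log units; within the scatter) from compound 2 to compound 4, 1.6-fold (0.20 log units) apart, within the scatter of two such steps. Across these four compounds, then, both changes carry from one core to the other with no gap beyond the scatter, but every step also stays within the scatter, and this does not show that either change has a real effect of its own or that the agreement would hold on a further core.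

Still open, as far as these compounds go, is whether a longer chain or a chain ending in an amine on the aromatic nitrogen, or a methoxy group in place of the halogen, would give a step beyond the scatter. Whether the agreement holds outside this assay is open as well.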